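This account rests on a few compounds, and the source may have more. Where it says the series, first, only, none or still open, it means among the compounds named here.

Compound 1 `C#CCSc1nc(Nc2ccccc2)c2ccncc2n1`: 29400 nM
Compound 2 `C#CCSc1nc(Nc2ccccc2OC)c2ccncc2n1`: 4530 nM
Compound 3 `C#CCSc1nc(Nc2cccc(OC)c2)c2ccncc2n1`: 920 nM

In a functional assay on HepG2 cells (Homo sapiens) for inhibition, read by MTT assay, with a stated time of 72 h (a higher number here means a weaker inhibitor, a lower number a stronger inhibitor), compound 1 gives the highest number of the three measured compounds; compound 2 stands nearest to it and compound 3 furthest from it. Compound 4 `C#CCSc1nc(Nc2ccc(OC)cc2)c2ccncc2n1` has not yet been measured in this assay. It differs from compound 1 by methoxy in place of hydrogen on an aromatic carbon. Among the compounds with values here, two measured steps bear on this change, since each of them is also a methoxy put in place of a hydrogen on the same ring of the shared core, placed differently: a 6.5-fold lower number from compound 1 to compound 2 (0.81 log units; beyond the scatter) and a 32-fold lower number from compound 1 to compound 3 (1.50 log units; beyond the scatter). Both steps run in the same direction and both lie beyond the scatter, although they differ considerably in size. Within the data shown here, no measured compound carries the group at the place it takes in compound 4, so the size of that step cannot be read off directly. A lower number than that of compound 1 is therefore expected for compound 4, a 12-fold lower number from compound 1 to compound 4 (1.07 log units; beyond the scatter), with its size expected to fall somewhere between the two measured steps. The estimate for compound 4 in this assay is 2500 nM, with a range from 400 nM to 15000 nM.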

Compound 4, half-maximal inhibitory concentration: > 80000 nM
Compound 4 ended at the assay's limit; the forecaster's own chance of this, stated with the estimate: 3%; at least 32-fold (1.50 log units) between middle value and limit.
By their numbers in this assay, from the lowest: compound 3; then compound 2; then compound 1. At a limit, above all of these: compound 4.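

In this assay, methoxy in place of hydrogen at the carbon para to a large group moves the number the opposite way from the two earlier steps, with an at least 2.7-fold higher number from compound 1 to compound 4 (0.43 log units; beyond the scatter). The earlier compounds shown here showed this change only as a lower number, in a 6.5-fold lower number from compound 1 to compound 2 (0.81 log units; beyond the scatter) and in a 32-fold lower number from compound 1 to compound 3 (1.50 log units; beyond the scatter), so the direction of the step could have seemed settled for the ring as a whole; across compound 2, compound 3 and compound 4, it instead turns on where the methoxy sits. Compound 4 gives > 80000 nM, which is a limit of the assay and not a number, so this step has a known direction and a minimum size but no upper bound: the limit of > 80000 nM in this assay, at which 1 of the 4 values shown sits.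

The compounds shown leave open whether the higher number at this place belongs to methoxy in particular or would also come with another group there, such as a fluorine, a hydroxyl or an amine. They also leave open whether a longer chain such as ethoxy, or one of these other groups, would follow the same dependence on place around the ring.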